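The source may report more compounds than this note shows. Statements on the series, on what has been measured and on what is new or still open speak of the compounds shown alone.

Measured so far in a functional assay on PC-3 cells (Homo sapiens) for antiproliferative activity, read by MTT assay, with a stated time of 24 h; on this read-out lower numbers stand for stronger inhibition and higher numbers for weaker inhibition:
- Compound 1 `CCn1c(C(=O)NCC(=O)OC)ccc1C(CC)(CC)c1ccc(OCS(=O)(=O)c2ccccc2)c(C)c1`: > 50000 nM, a limit
- Compound 2 `CCn1c(C(=O)N[C@H](CC(=O)O)C(=O)O)ccc1C(CC)(CC)c1ccc(OCS(=O)(=O)c2ccccc2)c(C)c1`: > 50000 nM, a limit

Compound 2 has no numerical value on this read-out and stands only at a limit, > 50000 nM. Among the compounds with values here, the one other result, for compound 1, is also a limit, so the series so far consists of the limit of > 50000 nM in this assay, at which 2 of the 2 values shown sit.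

Compound 3 `CCn1c(C(=O)N[C@@H](CCC(=O)O)C(=O)O)ccc1C(CC)(CC)c1ccc(OCS(=O)(=O)c2ccccc2)c(C)c1` carries 1,3-dicarboxypropyl in place of 1,2-dicarboxyethyl on an amide-type nitrogen. Within the data shown here, the only measured step at this nitrogen is a step that the two limits leave unreadable from compound 1 to compound 2, which exchanged (methoxycarbonyl)methyl for 1,2-dicarboxyethyl. It offers no size to carry forward, and it indicates no direction for the new change.

Among the measured compounds shown here, with no measured step to suggest otherwise, no clear shift is expected in this assay, and the new compound is expected to stay in the same region. The expected step is a number no higher from compound 2 to compound 3 (the limit leaves the size open), an estimate that is only loosely defined.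

For compound 3 the estimated value is 50000 nM, with an expected range of 20000 nM to 100000 nM, and a report of only a limit is the likeliest outcome.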

Compound 3, half-maximal inhibitory concentration: > 50000 nM
Compound 3 was reported as a limit; the forecaster's own chance of this, stated with the estimate: 85%; the middle value lies on the limit itself.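

Compound 3 is reported only as a limit in this assay, like compound 1 and compound 2, so no step from compound 2 to compound 3 or from compound 1 to compound 3 can be read, and the series rests on one limit: the limit of > 50000 nM in this assay, at which 3 of the 3 values shown sit.

The compounds shown leave open whether exchanging 1,2-dicarboxyethyl for 1,3-dicarboxypropyl changes the read-out at all, and what value any of these compounds would have.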